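Moving the chlorine from compound 2 to compound 3

The source may report more compounds than this note shows. Statements on the series, on what has been measured and on what is new or still open speak of the compounds shown alone.

Measured in an ADME assay on HEL cells (Homo sapiens) for cytotoxicity; a lower number here means that less compound is tolerated, a higher number that more compound is tolerated:
compound 1 `O=C(COc1cccc2ccccc12)N/N=C/c1ccc(O)cc1`: 60.6 ug/mL
compound 2 `O=C(COc1cccc2ccccc12)N/N=C/c1ccccc1Cl`: 62.7 ug/mL

Of these two compounds, compound 2 cannot be told apart from compound 1. Compound 3 `O=C(COc1cccc2ccccc12)N/N=C/c1cccc(Cl)c1` has not yet been measured. It carries 3-chlorophenyl in place of 2-chlorophenyl on a carbon with a double bond to nitrogen. Within the data shown here, one measured step bears on this place: a 1.0-fold higher number from compound 1 to compound 2 (0.01 log units; within the scatter). That exchange of 4-hydroxyphenyl for 2-chlorophenyl left the number within the scatter. Among the measured compounds shown here, no measured pair yet shows what a new chlorine position does, so this reading is only indirect. The estimated step is a 1.0-fold lower number from compound 2 to compound 3 (0.02 log units; within the scatter) in this assay, and no change beyond the scatter is expected in either direction. For compound 3 the expected value is 60 ug/mL, with an estimated range from 35 ug/mL to 100 ug/mL.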

Compound 3, half-maximal cytotoxic concentration: 58.6 ug/mL
Beside the measured number, compound 3's estimate is 1.0-fold (0.01 log units) above it, and the stated range covers the measured number.
By their numbers in this assay, from the lowest: compounds 3, 1 and 2 (each within the scatter of the next).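

Within this assay, compound 2 and compound 3 form the first pair that differs only in where the chlorine sits on the phenyl ring, and the result is a 1.1-fold lower number from compound 2 to compound 3 (0.03 log units; within the scatter) in this read-out. The exchange of 4-hydroxyphenyl for 3-chlorophenyl gives a 1.0-fold lower number from compound 1 to compound 3 (0.01 log units; within the scatter) as well, so the three groups tested on the carbon with a double bond to nitrogen cannot be told apart here. No measurement at hand offers an explanation for this result.

The three compounds leave open whether an amine or a carboxylic acid on this phenyl ring would take the number beyond the scatter. They also do not show whether a longer chain in place of the phenyl ring, or any change to the shared core, would do so.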